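The compounds below may be only part of what the source reports. "The series", "measured", "known", "first", "only" and "open" are said of these compounds alone.

Measured so far in a physicochemical assay for lipophilicity, measured as octanol-water partition, at pH 7.4; a higher number here means a more lipophilic compound, a lower number a more polar compound:
compound 1 `CC(C)c1noc(N2CCC(Oc3cc(N4CCc5cc(C6CCCCC6=O)ccc54)ncn3)CC2)n1` gives 4.7
compound 2 `CC(C)SC(=O)N1CCC(Oc2cc(N3CCc4ccccc43)ncn2)CC1` gives 5.3
compound 3 `CCc1cnc(N2CCC(C(C)COC(=O)N3CCc4cc(S(C)(=O)=O)cc(F)c43)CC2)nc1` gives 3.6

Among these three numbers compound 1 stands second highest: compound 2 lies beyond the scatter above it, and compound 3 lies further, beyond the scatter below it. Compound 4 `CC(C)c1noc(N2CCC(Oc3cc(N4CCc5cc(N6CCC(O)CC6=O)ccc54)ncn3)CC2)n1` differs from compound 1 in a single place, (4-hydroxy-2-oxopiperidin-1-yl in place of 2-oxocyclohexyl on an aromatic carbon). For the measured compounds named here, no pair of measured compounds that differ in only one place is available, so the size of this step has to be guessed from the change itself. The group that enters brings a hydrogen-bond donor and an extra acceptor where the leaving group had none, so a step downward in this assay, clearly beyond the scatter, is expected. The estimated step is a number 1.30 log units lower from compound 1 to compound 4 (beyond the scatter). For compound 4 the expected value is 3.4, with a range from 2.8 to 4.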

Compound 4, distribution coefficient: 2.8
Compound 4: the middle estimate sits 0.60 log units above what was measured, within the range that was stated.
By their numbers in this assay, from the lowest: compound 4; then compound 3; then compound 1; then compound 2.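

For the compounds shown here, this is the first comparison in the set in which only one place changes: in this assay, 4-hydroxy-2-oxopiperidin-1-yl in place of 2-oxocyclohexyl gives a number 1.90 log units lower from compound 1 to compound 4 (beyond the scatter) and counts as a large step. On this aromatic carbon, then, exchanging one six-membered ring for another can move the number well beyond the scatter. Nothing measured here explains the size of the step.

Going by these compounds, the entering group differs from the leaving one in both its ring nitrogen and its hydroxy group, and the share of each remains open. Also open, on these data alone, is where a plain 2-oxopiperidin-1-yl or a morpholine ring on this carbon would fall.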